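The compounds below may be only part of what the source reports. "The series", "measured", "known", "first", "only" and "open" are said of these compounds alone.

Among the compounds with values here, in an ADME assay on L02 cells (Homo sapiens) for cytotoxicity, read by MTT assay, with a stated time of 24 h (on this read-out higher numbers stand for weaker inhibition and lower numbers for stronger inhibition), three related compounds have numbers so far: compound 1 `CN1C/C(=C\c2ccncc2)C(=O)/C(=C/c2ccccc2C(F)(F)F)C1` gives 15800 nM, compound 2 `O=C1/C(=C/c2ccncc2)CNC/C1=C\c1ccccc1F` gives 14700 nM, and compound 3 `O=C1/C(=C/c2cccnc2)CNC/C1=C\c1ccccc1C(F)(F)F` gives 11300 nM. All three numbers lie within the usual scatter of one another, so compound 3 stands level with the other two. Compound 4 `O=C1/C(=C/c2ccncc2)CNC/C1=C\c1ccccc1C(F)(F)F` differs from compound 3 in one place: pyridin-4-yl in place of pyridin-3-yl on a double-bonded chain carbon bound to a double-bonded ring carbon, with pyridin-4-yl in place of pyridin-3-yl on a double-bonded chain carbon bound to a double-bonded ring carbon. Compound 2 already carries pyridin-4-yl and gives 14700 nM, so no step beyond the scatter is expected in this assay. The expected change is a 1.2-fold higher number from compound 3 to compound 4 (0.06 log units; within the scatter). For compound 4, the estimated value is 13000 nM, with an expected range of 7500 nM to 22000 nM.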

Compound 4, half-maximal inhibitory concentration: 13400 nM
Compound 4: middle estimate off by 1.0-fold (0.01 log units), on the low side; low and high end bracket the measured number.
By their numbers in this assay, from the lowest: compounds 3, 4, 2 and 1 (each within the scatter of the next).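

In this assay pyridin-4-yl in place of pyridin-3-yl on a double-bonded chain carbon bound to a double-bonded ring carbon gives a 1.2-fold higher number from compound 3 to compound 4 (0.07 log units; within the scatter) so moving the pyridine attachment at this place shows no readable effect. Compound 4 also links the other compounds: trifluoromethyl in place of fluoro on an aromatic carbon gives a 1.1-fold lower number from compound 2 to compound 4 (0.04 log units; within the scatter) and hydrogen in place of methyl on an amine nitrogen in a ring gives a 1.2-fold lower number from compound 1 to compound 4 (0.07 log units; within the scatter) so neither change separates from the scatter either. Nothing shown explains these results. Still open, going by these compounds, is whether pyridin-2-yl, or a carboxylic acid-bearing ring, at this place would shift the number beyond the scatter.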